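The source may hold more compounds than are shown below. What is called first, only, known or untested is meant among the compounds shown, and "the series" means these compounds.

Of the compounds shown here, two from a shared core have been tested in a functional assay on HEK293 cells for activation of 5-hydroxytryptamine receptor 4 (Homo sapiens), read by cAMP accumulation; a lower number here means a smaller maximal response, a higher number a larger maximal response. Compound 1, with the structure `COc1cc(N)c(Cl)cc1C(=O)NCCN1CCNCC1`, carries a piperazine-bearing side chain; in this assay compound 1 reaches only a limit of the assay, > 100%. Compound 2, with the structure `CCCCCN1CCC(NC(=O)c2cc(Cl)c(N)cc2OC)CC1`, carries a pentyl chain on the ring amine nitrogen; in this assay compound 2 likewise reaches only a limit of the assay, > 100%. Both values sit at the same edge of the scale, as the evidence shows: the limit of > 100% in this assay, at which 2 of the 2 values shown sit. Where compound 2 stands is therefore known only as this limit, and no numbered difference between compound 1 and compound 2 can be read from the data.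

The step in question leads to compound 3, with the structure `COc1cc(N)c(Cl)cc1C(=O)NC1CCN(CCCCCCCCS(=O)(=O)O)CC1`. The change from compound 2 to compound 3 reads (3-sulfopropyl in place of hydrogen on a saturated chain carbon, five bonds along the chain from an amine nitrogen in a ring). Among the measured compounds shown here, no measured step of comparable kind is available here, so the direction of the expected step rests only on the fact that both measured compounds reach the limit. The estimated step from compound 2 to compound 3 is a number at least 5 percentage points lower from compound 2 to compound 3 (that floor lies within the scatter), which would lie within the usual scatter. For compound 3 the expected maximal response in this assay is 95%, within a range from 75% to 110%.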

Compound 3, intrinsic activity: the largest response reached, in percent of the reference agonist's: > 100%
Compound 3 was reported as a limit (the forecaster's own chance of this, stated with the estimate: 40%); middle value at least 5 percentage points away from the limit.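

In this assay compound 3 gives > 100%, which is a limit of the assay. Compound 2 is also known only as a limit, so no step from compound 2 to compound 3 can be read: the limit of > 100% in this assay, at which 3 of the 3 values shown sit.

The compounds shown leave open whether their maximal responses differ at all, and by how much.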